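The source may hold more compounds than are shown below. What is called first, only, known or untested is meant among the compounds shown, and "the series" means these compounds.

Compounds measured so far:
compound 1 `Cc1ccc(C(=O)N2CCN(c3nc(=O)c4cc(C(F)(F)F)cc([N+](=O)[O-])c4s3)CC2)cc1`, 6.7 ug/mL
compound 2 `O=C(C1CCC1)N1CCN(c2nc(=O)c3cc(C(F)(F)F)cc([N+](=O)[O-])c3s2)CC1`, 39.3 ug/mL

In a physicochemical assay for solubility, read by HPLC (on this read-out higher numbers stand for higher solubility and lower numbers for lower solubility), compound 2 gives 39.3 ug/mL, the higher of the two numbers; compound 1 gives 6.7 ug/mL. Among the compounds with values here, the one measured step is a 5.9-fold higher number from compound 1 to compound 2 (0.77 log units; beyond the scatter), a change from an aromatic ring to a small saturated ring on the carbonyl carbon.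

Compound 3 `CCCC(=O)N1CCN(c2nc(=O)c3cc(C(F)(F)F)cc([N+](=O)[O-])c3s2)CC1` differs from compound 2 by propyl in place of cyclobutyl on a carbonyl carbon. Within the data shown here, no measured step matches this change; the step from compound 1 to compound 2 concerns a different exchange and bears on it only loosely. A saturated ring and an open chain of similar size on the same carbonyl carbon are taken to be close, so the step from compound 2 to compound 3 is expected to stay within the scatter, a 1.1-fold higher number from compound 2 to compound 3 (0.06 log units; within the scatter). For compound 3 the expected value in this assay is 45 ug/mL, with a range from 20 ug/mL to 100 ug/mL.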

Compound 3, solubility: 2.46 ug/mL
The estimate for compound 3 lay 18-fold (1.26 log units) above the measured number; measured number outside the range, below it.
By their numbers in this assay, from the lowest: compound 3; then compound 1; then compound 2.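

In this assay, ring and open chain are not interchangeable on this carbonyl carbon: propyl in place of cyclobutyl gives a 16-fold lower number from compound 2 to compound 3 (1.20 log units; beyond the scatter) and is a large step, although only the cyclobutyl ring and one carbon separate the two groups as counted. Propyl in place of 4-methylphenyl gives a 2.7-fold lower number from compound 1 to compound 3 (0.44 log units; beyond the scatter) in the same direction, so among these three groups the open chain reads lowest, the aromatic ring sits in the middle and the saturated ring reads highest. No measurement on hand accounts for this order.

Going by these compounds, whether the higher number belongs to saturated rings in general or to cyclobutyl alone stays open. Also open, on these data alone, is how butyl, a branched chain such as isopropyl, or a cyclopentyl or piperidine ring would read on this carbonyl carbon.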